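The source may hold more compounds than are shown below. What is called first, only, known or untested is meant among the compounds shown, and "the series" means these compounds.

Measured compounds:
Compound 1 `O=C1C=CC(O)(c2cc3ccc(F)cc3n2S(=O)(=O)c2ccccc2)C=C1` gives 16 nM
Compound 2 `O=C1C=CC(O)(c2cc3ccccc3n2S(=O)(=O)c2ccccc2)C=C1` gives 39 nM
Compound 3 `COc1ccc(S(=O)(=O)n2c(C3(O)C=CC(=O)C=C3)cc3ccccc32)cc1` gives 160 nM

In a functional assay on cells (Panel NCI-60 (60 carcinoma cell lines), Homo sapiens) (on this read-out higher numbers stand for weaker inhibition of growth and lower numbers for stronger inhibition of growth), compound 2 stands second highest of the three numbers. Its nearest neighbour is compound 1, reached by reversing the step of a 2.4-fold higher number from compound 1 to compound 2 (0.39 log units; beyond the scatter); its furthest is compound 3, reached by the step of a 4.1-fold higher number from compound 2 to compound 3 (0.61 log units; beyond the scatter).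

Compound 4 `COc1ccc2c(c1)cc(C1(O)C=CC(=O)C=C1)n2S(=O)(=O)c1ccccc1` is not yet measured. It differs from compound 2 in one place: methoxy in place of hydrogen on an aromatic carbon.

Among the measured compounds shown here, two measured steps bear on this change, though neither matches it exactly. The step from compound 1 to compound 2 concerns the same six-membered aromatic ring of carbon only, where removing a fluoro gave a 2.4-fold higher number from compound 1 to compound 2 (0.39 log units; beyond the scatter), so a small group on that ring went with somewhat stronger inhibition. The step from compound 2 to compound 3 involves the same entering group, methoxy, but at a different position, and gave a 4.1-fold higher number from compound 2 to compound 3 (0.61 log units; beyond the scatter), a modest weakening. Weighing a methoxy that weakened elsewhere against a ring that accepted a fluoro, the expectation for compound 4 is a small step, most likely a modest weakening or none beyond the scatter, a 1.5-fold higher number from compound 2 to compound 4 (0.19 log units; within the scatter). Compound 4 is therefore estimated at 60 nM, with a range from 20 nM to 200 nM.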

Compound 4, concentration for 50% growth inhibition: 130 nM
Beside the measured number, compound 4's estimate is 2.2-fold (0.34 log units) below it; measured number inside the range.
By their numbers in this assay, from the lowest: compound 1; then compound 2; then compounds 4 and 3 (each within the scatter of the next).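

On the six-membered aromatic ring of carbon only, part of the fused system, methoxy in place of hydrogen does not leave growth inhibition unchanged in this assay: it gives a 3.3-fold higher number from compound 2 to compound 4 (0.52 log units; beyond the scatter), a modest weakening beyond the scatter. The earlier compounds showed a methoxy weakening inhibition only at a different position, in compound 3, and a fluoro on this same ring going with stronger inhibition, in compound 1; now methoxy has gone with weaker inhibition at both positions shown, so this ring does not treat every group alike. No measurement shown here explains why the methoxy has this effect.

Going by these compounds, what remains open is whether the loss belongs to methoxy itself or would also appear with other groups on this aromatic carbon, such as a hydroxyl, a chloro or an ethoxy. On these data alone, it is also open whether a fluoro placed on this exact carbon would match the stronger inhibition seen with compound 1, which would show how much the position matters compared with the group.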